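Replacing Methoxy with Methylsulfanyl: an Expected Cytotoxicity

A few compounds are considered here, and "the series" means these few. Any claim that something is new, unique, unknown or untested is made for them only; others in the source may bear on it.

Of the compounds shown here, two have been tested in an ADME assay on BEAS-2B cells (Homo sapiens) for cytotoxicity, read by MTT assay, with a stated time of 72 h; a higher number here means a weaker inhibitor of growth, a lower number a stronger inhibitor of growth. Compound 1, `COc1ccc(CNc2nc([Se]C)nc3ccccc23)cc1`, gives > 100000 nM, which is a limit of the assay rather than a number. Going by the values given here, compound 2, `COc1ccc(CNc2nc([SeH])nc3ccccc23)cc1`, gives 37400 nM in this assay, and among the values shown it is the only one that is a number. The change from compound 1 to compound 2 is hydrogen in place of methyl on a selenium, and the step was an at least 2.6-fold lower number from compound 1 to compound 2 (0.42 log units; beyond the scatter).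

Compound 3, `CSc1ccc(CNc2nc([SeH])nc3ccccc23)cc1`, has not yet been measured. It differs from compound 2 by methylsulfanyl in place of methoxy on an aromatic carbon. Among the compounds with values here, the only measured step concerns the group on the selenium, not the substituent on the aromatic ring, so no measured step bears on this change. The step expected in this assay is a 1.0-fold lower number from compound 2 to compound 3 (0.00 log units; within the scatter), within the scatter. Compound 3 is therefore estimated to give 37000 nM in this assay, between 15000 nM and 100000 nM.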

Compound 3, concentration for 50% growth inhibition: 410 nM
Beside the measured number, compound 3's estimate is 90-fold (1.96 log units) above it; the measured number lies below the stated range.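

In this assay, methylsulfanyl in place of methoxy on an aromatic carbon, para to a large group, gives a 91-fold lower number from compound 2 to compound 3 (1.96 log units; beyond the scatter) as the largest change shown for a swap of a single atom, sulfur for oxygen. Going by these compounds alone, the only earlier step lay on the selenium, and this is the first sign that the ring substituent strongly affects growth inhibition in these cells, even though both groups have the same counts of heavy atoms and hydrogen-bond acceptors. Nothing measured here accounts for the size of this step.

From the compounds shown here alone, it remains open whether other groups at this place, such as an amine, a chlorine or a longer chain on the sulfur, would give a similar number. Going by these compounds, it is also open whether methylsulfanyl would have a similar effect with methyl on the selenium, as in compound 1, whose reading is only a limit.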